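Ether Swap on the Core of Compound 3: Expected Potency

The source may hold more compounds than are shown below. What is called first, only, known or untested is meant among the compounds shown, and "the series" means these compounds.

Measured compounds:
Compound 1 `COCc1nnc(C2CCN(Cc3ccc(F)cc3Cl)CC2)n1-c1ccc(OC)nc1`: 2790 nM
Compound 2 `COCc1nnc(N2CCC(c3ccc(F)cc3Cl)C2)n1-c1ccc(OC)nc1`: 27 nM
Compound 3 `COc1ccc(-n2c(COCCF)nnc2N2C[C@@H]3C[C@]3(c3ccc(F)cc3Cl)C2)cn1`: 44 nM

Of the compounds shown here, three have been tested in a functional assay on HEK293 cells for antagonist activity at Oxytocin receptor (Homo sapiens), read by calcium flux, with a stated time of 10 min, in the presence of a further agent that is not named here; a lower number here means a stronger inhibitor, a higher number a weaker inhibitor. Compound 1 gives 2790 nM, compound 2 gives 27 nM, and compound 3 gives 44 nM. On these numbers compound 3 sits close to compound 2, the two values being within the usual scatter of each other, while compound 1 lies far from both, a gap that is beyond the scatter.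

Compound 4 `COc1ccc(-n2c(CO[C@@H]3CCOC3)nnc2N2C[C@@H]3C[C@]3(c3ccc(F)cc3Cl)C2)cn1` has not yet been measured in this assay. It differs from compound 3 in one place: oxolan-3-yl in place of 2-fluoroethyl on an oxygen on a saturated carbon. Going by the values given here, no pair of measured compounds differs by a single change, so there is no measured step to lean on for this swap. Given that compound 3 gives 44 nM, the expectation for compound 4 is a step of a 1.1-fold lower number from compound 3 to compound 4 (0.04 log units; within the scatter) that stays within the scatter, with no clear direction. Compound 4 is therefore estimated at 40 nM, with a likely range from 15 nM to 120 nM.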

Compound 4, half-maximal inhibitory concentration: 223 nM
Estimate against measurement, compound 4: 5.6-fold (0.75 log units) below; measured number outside the range, above it.
By their numbers in this assay, from the lowest: compounds 2 and 3 (each within the scatter of the next); then compound 4; then compound 1.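

Putting oxolan-3-yl in place of 2-fluoroethyl on an oxygen on a saturated carbon gives a 5.1-fold higher number from compound 3 to compound 4 (0.70 log units; beyond the scatter) in this assay and is the only single-place step among the compounds shown. It shows that the reading at this position depends on the group carried on that oxygen, and here the entering group, with its five-membered ring, one hydrogen-bond acceptor and defined stereocentre, goes with the weaker inhibitor. Nothing available indicates which of these features accounts for the step.

As far as these compounds go, this one step cannot separate the ring from its oxygen, so it remains open whether a cyclopentyl group or the opposite stereoisomer of oxolan-3-yl would read closer to compound 3. From the compounds shown here alone, how a plain ethyl group or a longer chain such as 3-fluoropropyl would read on this oxygen also remains open.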